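Phenoxy to benzyl exchange on the thiadiazole amide series

The source may hold more compounds than are shown below. What is called first, only, known or untested is meant among the compounds shown, and "the series" means these compounds.

The series shares a core carrying a propanoic acid chain, exemplified by compound 1 `Cc1ccc(OCc2nnc(C(=O)Nc3ccc(CCC(=O)O)cc3)s2)c(C)c1`. In a functional assay on CHO cells for agonist activity at Free fatty acid receptor 1 (Homo sapiens), read by FLIPR and calcium flux, tested at 1 uM (a lower number here means that less compound is needed, a higher number that more compound is needed for the effect), compound 1 gives 2540 nM, the lowest of the two numbers, though compound 2 `O=C(O)CCc1ccc(NC(=O)c2nnc(COc3cccc(C(F)(F)F)c3)s2)cc1` gives 3090 nM and the step of a 1.2-fold higher number from compound 1 to compound 2 (0.09 log units; within the scatter) does not separate them.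

Compound 3 `O=C(O)CCc1ccc(NC(=O)c2nnc(Cc3cccc(F)c3)s2)cc1` differs from compound 1 by 3-fluorophenyl in place of 2,4-dimethylphenoxy on a saturated chain carbon bound to an aromatic carbon. Going by the values given here, the only measured step, from compound 1 to compound 2, exchanges one aryl group for another while keeping the oxygen on the saturated carbon, so it bears only loosely on this change, and it was small. Among the compounds with values here, no measured pair removes the oxygen or shrinks the group to a 3-fluorophenyl. Within the data shown here, the expectation is therefore a step of a 1.3-fold higher number from compound 1 to compound 3 (0.10 log units; within the scatter), not beyond the scatter, with wide uncertainty because the step of a 1.2-fold higher number from compound 1 to compound 2 (0.09 log units; within the scatter) is the sole guide. Compound 3 is estimated at 3200 nM, within 1000 nM to 10000 nM.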

Compound 3, half-maximal effective concentration: 5020 nM
The estimate for compound 3 lay 1.6-fold (0.20 log units) below the measured number; the measured number falls inside the stated range.
By their numbers in this assay, from the lowest: compounds 1, 2 and 3 (each within the scatter of the next).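

In this assay, the 2,4-dimethylphenoxy group on the saturated chain carbon bound to an aromatic carbon gives way to 3-fluorophenyl, and the result is a 2.0-fold higher number from compound 1 to compound 3 (0.30 log units; within the scatter). Unlike the earlier step, this change removes the oxygen from the saturated carbon as well as exchanging the aryl group, and the step still stays within the scatter, so the oxygen is not shown to be needed for the activity seen in this small set. No measured information on the cause of this outcome is available.

Going by these compounds alone, the single step bundles the loss of the oxygen with the change of ring substituents, and 3-fluorophenoxy on the same carbon would separate the two. Also open, on these data alone, is whether an amine at that carbon, or a longer chain carrying the aryl group, would stay within the scatter of compound 1.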